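A few compounds are considered here, and "the series" means these few. Any claim that something is new, unique, unknown or untested is made for them only; others in the source may bear on it.

In an ADME assay on Vero cells (Chlorocebus sabaeus) for cytotoxicity (a higher number here means that more compound is tolerated, a lower number that less compound is tolerated), three compounds have been measured so far. Compound 1 `c1cc(NC2CCCC2)c2nc(-c3ccc(OCC4CC4)cc3)c(-c3ccnc(NC4CCCC4)n3)n2c1` reports only a limit, > 40000 nM. Compound 2 `Fc1ccc(-c2nc3c(NC4CC4)cccn3c2-c2ccnc(NC3CCCC3)n2)cc1` gives 33000 nM. Compound 3 `CCCCNc1cccn2c(-c3ccnc(NC4CCCC4)n3)c(-c3ccc(F)cc3)nc12` gives 32000 nM, which lies within the scatter of compound 2, so the two stand level.

The next compound, compound 4 `COCCNc1cccn2c(-c3ccnc(NC4CCCC4)n3)c(-c3ccc(F)cc3)nc12`, has not yet been measured. It differs from compound 3 by a small edit, methoxy in place of ethyl on a saturated chain carbon, two bonds along the chain from a nitrogen on an aromatic ring. Butylamino thus becomes (2-methoxyethyl)amino.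

For the measured compounds named here, only one measured step bears on this: butyl in place of cyclopropyl on a nitrogen on an aromatic ring, which gave a 1.0-fold lower number from compound 2 to compound 3 (0.01 log units; within the scatter). With that single step as a guide, no shift beyond the scatter is expected here. The expected step is a 1.0-fold higher number from compound 3 to compound 4 (0.01 log units; within the scatter). For compound 4, the estimated value is 33000 nM, with an expected range of 17000 nM to 40000 nM.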

Compound 4, half-maximal cytotoxic concentration: > 40000 nM
Compound 4: only a limit was reported (the forecaster's own chance of this, stated with the estimate: 35%); middle value at least 1.2-fold (0.08 log units) from the limit.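

In this assay compound 4 gives > 40000 nM, which is a limit and not a number. Methoxy in place of ethyl gives an at least 1.2-fold higher number from compound 3 to compound 4 (0.09 log units; that floor lies within the scatter), and 2-methoxyethyl in place of cyclopropyl gives an at least 1.2-fold higher number from compound 2 to compound 4 (0.08 log units; that floor lies within the scatter). An oxygen can therefore enter this chain, adding one hydrogen-bond acceptor by the count of the two groups, with no sign of a lower number, but neither floor shows a real gain and the true size of either step stays hidden: the limit of > 40000 nM in this assay, at which 2 of the 4 values shown sit.

Open, as far as these compounds go, is how an amine or a carboxylic acid in place of methoxy would read in this assay. From the compounds shown here alone, a longer chain carrying the same methoxy is equally open, and only such neighbours could show how much change this position tolerates.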